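Adding a chloro group to the phenyl ring of compound 3

A few compounds are considered here, and "the series" means these few. Any claim that something is new, unique, unknown or untested is made for them only; others in the source may bear on it.

Measured compounds:
- compound 1 `Cc1nc(-c2cccnc2)sc1-c1nnc(Cc2ccccc2)o1` — > 100 ug/mL
- compound 2 `Cc1nc(-c2cccnc2)sc1-c1nnc(-c2ccccc2Cl)o1` — > 100 ug/mL
- compound 3 `Cc1nc(-c2cccnc2)sc1-c1nnc(-c2ccccc2)o1` — > 100 ug/mL

All three share one core and differ only in the group attached to it. In an ADME assay on HeLa cells (Homo sapiens) for cytotoxicity, read by MTT assay (a higher number here means that more compound is tolerated, a lower number that less compound is tolerated), compound 1 gives > 100 ug/mL, which is a limit of the assay and not a number. In this assay compound 2 gives > 100 ug/mL, also a limit. Compound 3 gives > 100 ug/mL in this assay, again a limit. Because of the limit of > 100 ug/mL in this assay, at which 3 of the 3 values shown sit, none of the steps between them can be sized: a step that the two limits leave unreadable from compound 1 to compound 2, a step that the two limits leave unreadable from compound 1 to compound 3 and a step that the two limits leave unreadable from compound 2 to compound 3 all stay unreadable. So compound 3 stands at the limit, alongside the two other measured compounds.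

Compound 4 `Cc1nc(-c2cccnc2)sc1-c1nnc(-c2ccc(Cl)cc2)o1` is the next compound. It differs from compound 3 in one place: chloro in place of hydrogen on an aromatic carbon. Among the compounds with values here, the measured step that bears most closely on it is the one from compound 2 to compound 3, where a chloro also leaves a phenyl ring, but that step that the two limits leave unreadable from compound 2 to compound 3 gives no size to work from. The expectation is therefore no step beyond the scatter in this assay, most likely another limit. Compound 4 is expected at 100 ug/mL, with a range from 50 ug/mL to 200 ug/mL, which means an expected step of a number no higher from compound 3 to compound 4 (the limit leaves the size open).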

Compound 4, half-maximal cytotoxic concentration: > 100 ug/mL
Compound 4: no number, only a limit (the forecaster's own chance of this, stated with the estimate: 85%); the middle value lies on the limit itself.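

In this assay compound 4 gives > 100 ug/mL, which is a limit of the assay and not a number. The steps from compound 1, compound 2 and compound 3 to compound 4 therefore cannot be read, because of one shared limit: the limit of > 100 ug/mL in this assay, at which 4 of the 4 values shown sit. The compounds shown leave open whether these four differ at all in this assay.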